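A few compounds are considered here, and "the series" means these few. Any claim that something is new, unique, unknown or untested is made for them only; others in the source may bear on it.

Three compounds here share a core in which a carbon with a double bond to nitrogen carries two amide-type nitrogens, each acylated by an aromatic unit. Compound 1, `C[Se]/C(=N\C(=O)c1cccs1)NC(=O)c1cccs1`, bears a methyl group on selenium; in a functional assay on HepG2 cells (Homo sapiens) for cytotoxicity, read by MTT assay, with a stated time of 72 h (a lower number here means a stronger inhibitor of growth, a higher number a weaker inhibitor of growth), compound 1 gives 630 nM. Compound 2, `CS/C(=N\C(=O)c1sccc1Cl)NC(=O)c1sccc1Cl`, bears methylsulfanyl and chlorinated acyl units; in this assay compound 2 gives 65300 nM. Compound 3, `C[Se]/C(=N\C(=O)c1cnc2ccccc2c1)NC(=O)c1cnc2ccccc2c1`, returns to the selenium group with a larger fused acyl unit; in this assay compound 3 gives 4160 nM, the second highest of the three numbers. Nearest to compound 3 stands compound 1 with 630 nM, furthest compound 2 with 65300 nM; both gaps lie beyond the scatter.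

Compound 4, `CS/C(=N\C(=O)c1cnc2ccccc2c1)NC(=O)c1cnc2ccccc2c1`, differs from compound 3 by a group of 2 heavy atoms (1 carbon, 1 sulfur; no ring) in place of a group of 2 heavy atoms (1 carbon, 1 selenium; no ring), on a carbon with a double bond to nitrogen. Among the measured compounds shown here, no measured pair differs in this one place alone. Compound 1 and compound 2 differ in this group but also in their acyl units; compound 1 gives 630 nM and compound 2 gives 65300 nM, a wide gap in which the methylsulfanyl compound is far weaker. On that ground the step of a 7.2-fold higher number from compound 3 to compound 4 (0.86 log units; beyond the scatter) is expected to be a rise beyond the scatter. Compound 4 is therefore estimated at 30000 nM, within a range from 8000 nM to 150000 nM.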

Compound 4, concentration for 50% growth inhibition: 57600 nM
Compound 4: the middle estimate sits 1.9-fold (0.28 log units) below what was measured, and the stated range covers the measured number.
By their numbers in this assay, from the lowest: compound 1; then compound 3; then compounds 4 and 2 (each within the scatter of the next).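

Replacing the selenium-bearing group with methylsulfanyl, on a carbon with a double bond to nitrogen whose other neighbours are amide-type nitrogen, amide-type nitrogen, gives in this assay a 14-fold higher number from compound 3 to compound 4 (1.14 log units; beyond the scatter) and is a large step. Among the compounds shown here, this is the first pair in which that group changes alone, with the acyl units held the same, so the rise in the number belongs to this one place and is no longer mixed with a change in the acyl units, as it was among the earlier compounds. Nothing measured here bears on what lies behind the step.

The compounds shown leave open whether the step keeps its size with other acyl units, such as those of compound 1. They also leave open how, in this assay and at this same place, a longer chain on selenium, such as ethyl, or an amine would compare with the methyl group on selenium in compound 3.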